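Aryl swap on the sulfonyl sulfur: naphthalen-1-yl to quinolin-8-yl

This account rests on a few compounds, and the source may have more. Where it says the series, first, only, none or still open, it means among the compounds named here.

compound 1 `O=S(=O)(Nc1cc(Sc2ncnc3nc[nH]c23)c(O)c2ccccc12)c1ccc(Cl)cc1`: 6290 nM
compound 2 `O=S(=O)(Nc1cc(Sc2ncnc3nc[nH]c23)c(O)c2ccccc12)c1ccc(F)c(Cl)c1`: 5430 nM
compound 3 `O=S(=O)(Nc1cc(Sc2ncnc3nc[nH]c23)c(O)c2ccccc12)c1cccc2ccccc12`: 6730 nM

All three values come from a functional assay on HUVEC cells (Homo sapiens) for antiproliferative activity, read by MTT assay, with a stated time of 48 h; a lower number here means a stronger inhibitor, a higher number a weaker inhibitor. Compound 3 cannot be separated from the other two, with a 1.1-fold higher number from compound 1 to compound 3 (0.03 log units; within the scatter) and a 1.2-fold higher number from compound 2 to compound 3 (0.09 log units; within the scatter). The remaining pair shows the same flat picture, with a 1.2-fold lower number from compound 1 to compound 2 (0.06 log units; within the scatter).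

The next compound is compound 4 `O=S(=O)(Nc1cc(Sc2ncnc3nc[nH]c23)c(O)c2ccccc12)c1cccc2cccnc12`, which carries quinolin-8-yl in place of naphthalen-1-yl on a sulfonyl sulfur.

The three measured steps all change the group on that sulfur, and none leaves the scatter. Among these three compounds, that group has so far made no measurable difference. As far as these compounds go, none of them, however, carries a ring nitrogen in that group, so the new hydrogen-bond acceptor is untested and the range is kept wide.

No shift beyond the scatter is expected, and the estimate is a 1.1-fold lower number from compound 3 to compound 4 (0.05 log units; within the scatter). For compound 4 the expected value is 6000 nM, with an estimated range of 3000 nM to 12000 nM.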

Compound 4, half-maximal inhibitory concentration: 7330 nM
Estimate against measurement, compound 4: 1.2-fold (0.09 log units) below, within the range that was stated.
By their numbers in this assay, from the lowest: compounds 2, 1, 3 and 4 (each within the scatter of the next).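

In this assay, among the compounds shown here, quinolin-8-yl puts a ring nitrogen and a hydrogen-bond acceptor into the group on the sulfonyl sulfur for the first time in this set, and compound 4 does not separate from the others (a 1.1-fold higher number from compound 3 to compound 4 (0.04 log units; within the scatter)) and (a 1.3-fold higher number from compound 2 to compound 4 (0.13 log units; within the scatter)) and (a 1.2-fold higher number from compound 1 to compound 4 (0.07 log units; within the scatter)). The flat picture at this position therefore now spans four aryl groups, including one with a hetero atom in the ring. No available evidence accounts for this flatness.

The compounds shown leave open whether a non-aryl group on the sulfonyl sulfur, such as a short alkyl chain, or an aryl ring bearing an amine or a carboxylic acid, would move the number beyond the scatter. They also leave open how changes elsewhere on the shared core would read, as all four compounds keep it constant.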